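The compounds below may be only part of what the source reports. "The series", "measured", "known", "first", "only" and "open" are said of these compounds alone.

Compounds measured so far:
compound 1 `O=C(N/N=C/c1ccc(F)cc1Cl)Nc1ccc(Oc2ccnc3[nH]ccc23)c(F)c1` — 3 nM
compound 2 `O=C(N/N=C/c1ccccc1)Nc1ccc(Oc2ccnc3[nH]ccc23)cc1` — 10200 nM
compound 3 `COc1ccc(/C=N/NC(=O)Nc2ccc(Oc3ccnc4[nH]ccc34)cc2)c(OC)c1OC` — 27600 nM

In a functional assay on PC-3 cells (Homo sapiens) for antiproliferative activity, read by MTT assay, with a stated time of 72 h (on this read-out higher numbers stand for weaker inhibition and lower numbers for stronger inhibition), compound 2 gives 10200 nM, the second highest of the three numbers. Its nearest neighbour is compound 3, which in this assay gives 27600 nM, a higher number beyond the usual scatter. Far away stands compound 1, which in this assay gives 3 nM, a much lower number; compound 1 differs from compound 2 in more than one place, so no single change can be read from that pair.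

Compound 4 `CN(C)CCCn1cccc1/C=N/NC(=O)Nc1ccc(Oc2ccnc3[nH]ccc23)cc1` has not yet been measured. It differs from compound 2 in one place: 1-(3-(dimethylamino)propyl)-1H-pyrrol-2-yl in place of phenyl on a carbon with a double bond to nitrogen. Within the data shown here, no measured pair shows this change, so there is no step to lean on. Given the weak number of compound 2 in this assay, a modest move toward a lower number is expected, likely not far beyond the scatter. Compound 4 is therefore estimated at 6000 nM, within 1000 nM to 30000 nM, which means an expected step of a 1.7-fold lower number from compound 2 to compound 4 (0.23 log units; within the scatter).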

Compound 4, half-maximal inhibitory concentration: 5150 nM
Compound 4: middle estimate off by 1.2-fold (0.07 log units), on the high side, and the stated range covers the measured number.
By their numbers in this assay, from the lowest: compound 1; then compounds 4 and 2 (each within the scatter of the next); then compound 3.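

In this assay, swapping the phenyl group for the 1-(3-(dimethylamino)propyl)-1H-pyrrol-2-yl group gives a 2.0-fold lower number from compound 2 to compound 4 (0.30 log units; within the scatter), the first single-place step read at this position. It shows that this position can carry a five-membered aromatic ring with 1 hetero atom and 11 heavy atoms in place of 6, with 2 hydrogen-bond acceptors where phenyl has none, and the two numbers still cannot be told apart. Nothing measured here explains this result.

The compounds shown leave open what the 1H-pyrrol-2-yl group would give without its chain, and whether a shorter chain or a morpholine in place of the dimethylamino group would move the number beyond the scatter. They also leave open what a single chlorine or fluorine on the phenyl of compound 2 would do.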